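A few compounds are considered here, and "the series" means these few. Any claim that something is new, unique, unknown or untested is made for them only; others in the source may bear on it.

Three esters with a shared core have been tested in a functional assay on HeLa cells (Homo sapiens) for cytotoxicity, read by MTT assay; on this read-out higher numbers stand for weaker inhibition and lower numbers for stronger inhibition. There compound 1 `CCCC(O)CC(=O)O[C@H](CC=C(C)C)C1=CC(=O)c2c(O)ccc(O)c2C1=O` gives 59300 nM, compound 2 `CC(=O)OCCC(=O)O[C@H](CC=C(C)C)C1=CC(=O)c2c(O)ccc(O)c2C1=O` gives 17300 nM, and compound 3 `CCCCC(C)(O)CC(=O)O[C@H](CC=C(C)C)C1=CC(=O)c2c(O)ccc(O)c2C1=O` gives 60600 nM. Compound 3 therefore matches compound 1, with a 1.0-fold higher number from compound 1 to compound 3 (0.01 log units; within the scatter), and lies above compound 2. Compound 4 `CC(C)=CC[C@@H](OC(=O)c1ccoc1)C1=CC(=O)c2c(O)ccc(O)c2C1=O` carries furan-3-yl in place of 2-hydroxy-2-methylhexyl on a carbonyl carbon. For the measured compounds named here, no tested compound has a ring at this place, so the evidence is indirect. Furan-3-yl, like acetoxymethyl, has no hydroxy group, so the nearest guides are two modest steps: a 3.4-fold lower number from compound 1 to compound 2 (0.54 log units; beyond the scatter) and a 3.5-fold higher number from compound 2 to compound 3 (0.54 log units; beyond the scatter). A modest drop in this assay is therefore expected, and the expected step is a 2.4-fold lower number from compound 3 to compound 4 (0.38 log units; beyond the scatter). Compound 4 is estimated at 25000 nM, with a range from 7000 nM to 70000 nM.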

Compound 4, half-maximal inhibitory concentration: > 100000 nM
Compound 4 was reported as a limit (the forecaster's own chance of this, stated with the estimate: 5%); middle value at least 4.0-fold (0.60 log units) from the limit.
By their numbers in this assay, from the lowest: compound 2; then compounds 1 and 3 (each within the scatter of the next). At a limit, above all of these: compound 4.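

In this assay, for the compounds shown here, compound 4, the only compound here with a ring at this place, is reported just as a limit, > 100000 nM. Furan-3-yl in place of 2-acetoxyethyl gives an at least 5.7-fold higher number from compound 2 to compound 4 (0.76 log units; beyond the scatter), so having no hydroxy group does not by itself bring a lower number. Against the two hydroxy-bearing chains, the floors of an at least 1.6-fold higher number from compound 3 to compound 4 (0.21 log units; that floor lies within the scatter) and an at least 1.6-fold higher number from compound 1 to compound 4 (0.22 log units; that floor lies within the scatter) leave those comparisons undecided. Going by these compounds, the true value of compound 4 remains unknown. Also open, on these data alone, is whether a phenyl or cyclohexyl ring at this place would behave like furan-3-yl.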